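This account rests on a few compounds, and the source may have more. Where it says the series, first, only, none or still open, it means among the compounds named here.

Compound 1 `Cc1oc(S(=O)(=O)NC[C@H]2OC(O)[C@H](NC(=O)c3cccc(Br)c3)[C@@H](O)[C@@H]2O)cc1C(=O)O` gives 20 nM in an assay for inhibition of hexokinase-1 (Homo sapiens), read by ADP-Glo, with a stated time of 45 min, in the presence of a further agent that is not named here; a lower number here means a stronger inhibitor, a higher number a weaker inhibitor. Compound 2 `O=C(N[C@H]1C(O)O[C@H](CO)[C@@H](O)[C@@H]1O)c1cccc(-c2ccccc2)c1` gives 790 nM in this assay. Compound 3 `COC(=O)c1cc(S(=O)(=O)NC[C@H]2OC(O)[C@H](NC(=O)c3cccc(Br)c3)[C@@H](O)[C@@H]2O)oc1C` gives 1600 nM in this assay.

Compound 2 stands second highest of the three numbers, nearest to compound 3 and furthest from compound 1; the gap to compound 1 is large, while the gap to compound 3 is only just beyond the scatter. Compound 4 `O=C(N[C@H]1C(O)O[C@H](CNS(=O)(=O)c2cnccc2Cl)[C@@H](O)[C@@H]1O)c1cccc(-c2ccccc2)c1` differs from compound 2 in one place: a group of 11 heavy atoms (5 carbon, 2 nitrogen, 2 oxygen, 1 sulfur, 1 chlorine; one six-membered aromatic ring with 1 hetero atom) in place of one oxygen atom, on a saturated chain carbon bound to a saturated ring carbon. Going by the values given here, the only step measured in one place, an 80-fold higher number from compound 1 to compound 3 (1.90 log units; beyond the scatter), concerns the ester and not this chain, so it does not bear on the change. The values of compound 1 and compound 2 show that the compound carrying a sulfonamide-bearing chain sits far lower, but those two compounds differ elsewhere as well. The step is therefore expected to be downward, likely beyond the scatter, with a wide range. Compound 4 is estimated at 120 nM, between 25 nM and 600 nM, which is expected to mean a 6.6-fold lower number from compound 2 to compound 4 (0.82 log units; beyond the scatter).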

Compound 4, half-maximal inhibitory concentration: 20 nM
For compound 4 the middle estimate is 6.0-fold (0.78 log units) above the measured one; the whole stated range lies above it.
By their numbers in this assay, from the lowest: compounds 1 and 4 (each within the scatter of the next); then compound 2; then compound 3.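

On the saturated chain carbon bound to a saturated ring carbon, the hydroxy of compound 2 gives way to a group of 11 heavy atoms with one six-membered aromatic ring, and in this assay this change brings a 40-fold lower number from compound 2 to compound 4 (1.60 log units; beyond the scatter) as a large step beyond the scatter. It is the first step shown at this position, and it shows that the position accepts a far larger group than hydroxy and that the number falls steeply with this group in place. Nothing in the data accounts for the size of this step.

As far as these compounds go, the group enters as a whole, so the share of its sulfonamide link, its aromatic ring and its chlorine remains open. From the compounds shown here alone, it is also open whether a plain amine or a phenyl ring without chlorine at this place would give a similar step.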